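Removing the methyl from the phenolic oxygen of compound 2

This account rests on a few compounds, and the source may have more. Where it says the series, first, only, none or still open, it means among the compounds named here.

Compound 2 `COc1cc(-c2nn(-c3cccc(NC(=O)Nc4cc(C(F)(F)F)cc(C(F)(F)F)c4)c3)cc2-c2ccncc2)ccc1Cl` gives 4870 nM in a functional assay on SW-620 cells (Homo sapiens) for inhibition, read by sulforhodamine B assay, with a stated time of 48 h (on this read-out higher numbers stand for lower toxicity in this test and lower numbers for higher toxicity in this test), the lowest of the two numbers here. Compound 3 `COc1cc(-c2nn(-c3cccc(NC(=O)Nc4cccc(C(F)(F)F)c4)c3)cc2-c2ccncc2)ccc1Cl` gives 50000 nM in this assay, so the step of a 10-fold higher number from compound 2 to compound 3 (1.01 log units; beyond the scatter) is large. Compound 1 `O=C(Nc1cccc(-n2cc(-c3ccncc3)c(-c3ccc(Cl)c(O)c3)n2)c1)Nc1cccc(C(F)(F)F)c1` reaches only a limit in this assay, namely > 32500 nM. Compound 4 `O=C(Nc1cccc(-n2cc(-c3ccncc3)c(-c3ccc(Cl)c(O)c3)n2)c1)Nc1cc(C(F)(F)F)cc(C(F)(F)F)c1` differs from compound 2 by hydrogen in place of methyl on an oxygen on an aromatic ring. Among the compounds with values here, the one measured step touching this same change, a step that the limit leaves unreadable from compound 1 to compound 3, cannot be read because of the limit of > 32500 nM in this assay, at which 1 of the 3 values shown sits. The measured steps thus give no direction for the change to compound 4. Compound 4 is estimated at 7000 nM, between 2000 nM and 30000 nM. The step of a 1.4-fold higher number from compound 2 to compound 4 (0.16 log units; within the scatter) is expected to stay within the scatter.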

Compound 4, concentration lethal to 50% of the cells: 23400 nM
Compound 4: middle estimate off by 3.3-fold (0.52 log units), on the low side; low and high end bracket the measured number.
By their numbers in this assay, from the lowest: compound 2; then compound 4; then compound 3.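

On this position, the change from methoxy to hydroxy now has a readable size in this assay: a 4.8-fold higher number from compound 2 to compound 4 (0.68 log units; beyond the scatter). On the hydroxy compounds, adding a trifluoromethyl gives an at least 1.3-fold lower number from compound 1 to compound 4 (0.14 log units; that floor lies within the scatter), which is only a floor. The value of compound 1, > 32500 nM, is a limit.

From the compounds shown here alone, it stays open whether the trifluoromethyl change has the same size with methoxy and with hydroxy: the same change on two cores in this assay, a 10-fold higher number (1.01 log units; beyond the scatter) from compound 2 to compound 3 and an at least 1.3-fold higher number (0.14 log units; that floor lies within the scatter) from compound 4 to compound 1; the limit leaves it open whether they differ Also open is how an amine or a carboxylic acid would read in place of the hydroxy on the aromatic ring.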